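Piperazine for Piperidine on a Second Stereoisomer

The source may hold more compounds than are shown below. What is called first, only, known or untested is meant among the compounds shown, and "the series" means these compounds.

Compound 1 `C/C1=C\CC[C@@]2(C)O[C@@H]2[C@H]2OC(=O)[C@@H](CN3CCCCC3)[C@@H]2C[C@H]1O` and compound 3 `C/C1=C\CC[C@@]2(C)O[C@@H]2[C@H]2OC(=O)[C@@H](CN3CCCCC3)[C@@H]2C[C@@H]1O` are built from the same atoms and bonds; their cores differ only as drawn, (the two compounds have the same atoms and bonds and differ only in configuration as drawn: 1 of 7 stereo elements differ; a stereocentre at a saturated ring carbon is drawn R in compound 1 and S in compound 3). In a functional assay on MCF7 cells (Homo sapiens) for inhibition, read by MTT assay, with a stated time of 72 h (a higher number here means a weaker inhibitor, a lower number a stronger inhibitor), compound 1 gives 16000 nM, while compound 3 gives 8000 nM, which is a 2.0-fold lower number from compound 1 to compound 3 (0.30 log units; within the scatter), and this rests on (the fact that compounds 1 and 3 differ only in the configuration as drawn). Compound 2 `C/C1=C\CC[C@@]2(C)O[C@@H]2[C@H]2OC(=O)[C@@H](CN3CCN(C)CC3)[C@@H]2C[C@H]1O` differs from compound 1 in one place: 4-methylpiperazin-1-yl in place of piperidin-1-yl on a saturated chain carbon bound to a saturated ring carbon. In this assay compound 2 gives 33000 nM, so that change made a 2.1-fold higher number from compound 1 to compound 2 (0.31 log units; beyond the scatter). Compound 4 `C/C1=C\CC[C@@]2(C)O[C@@H]2[C@H]2OC(=O)[C@@H](CN3CCN(C)CC3)[C@@H]2C[C@@H]1O` carries the same change on the core of compound 3: 4-methylpiperazin-1-yl in place of piperidin-1-yl on a saturated chain carbon bound to a saturated ring carbon. For the measured compounds named here, this change appears twice among the four compounds, with only one instance measured. Compound 4 is therefore expected to give 17000 nM in this assay. That estimate means an expected 2.1-fold higher number from compound 3 to compound 4 (0.33 log units; beyond the scatter), matching a 2.1-fold higher number from compound 1 to compound 2 (0.31 log units; beyond the scatter).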

Compound 4, half-maximal inhibitory concentration: 22000 nM
For compound 4 the middle estimate is 1.3-fold (0.11 log units) below the measured one; the measured number falls inside the stated range.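

In this assay the same exchange of piperidin-1-yl for 4-methylpiperazin-1-yl on the core of compound 3 gave a 2.8-fold higher number from compound 3 to compound 4 (0.44 log units; beyond the scatter), and the two instances agree: the same change on two cores in this assay, a 2.1-fold higher number (0.31 log units; beyond the scatter) from compound 1 to compound 2 and a 2.8-fold higher number (0.44 log units; beyond the scatter) from compound 3 to compound 4, 1.3-fold (0.12 log units) apart, within the scatter of two such steps. The configuration step within the 4-methylpiperazin-1-yl pair is a 1.5-fold lower number from compound 2 to compound 4 (0.18 log units; within the scatter), which is a change of configuration alone: the fact that compounds 2 and 4 differ only in the configuration as drawn. So the change carried over between these two cores, but they differ at only one drawn stereocentre, and this shows nothing about a core altered in any other way or about any other assay.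

The compounds shown leave open whether another amine, such as morpholin-4-yl or dimethylamino, in the same place would follow the same step on both cores.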